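The source may hold more compounds than are shown below. What is called first, only, known or untested is meant among the compounds shown, and "the series" means these compounds.

Compound 3 `Cc1ccnc(/C(N)=N/NC(=S)N2CCSCC2)c1` and compound 1 `Cc1ccnc(/C(N)=N/NC(=S)N2CCOCC2)c1` share one core and differ only in the ring attached to the thiocarbonyl carbon. In a functional assay on HeLa cells (Homo sapiens) for cytotoxicity, read by MTT assay, with a stated time of 72 h, tested at 3 uM (on this read-out higher numbers stand for more inhibition of growth at the one concentration tested and lower numbers for less inhibition of growth), compound 3 gives 40.4% and compound 1 gives 44.7%; the change morpholin-4-yl in place of thiomorpholin-4-yl on a thiocarbonyl carbon moved the number a number 4.3 percentage points higher from compound 3 to compound 1 (within the scatter). Compound 2 `Cc1cccc(/C(N)=N/NC(=S)N2CCSCC2)n1` carries the same thiomorpholin-4-yl group as compound 3 but on a core built from the same atoms joined differently; the difference between the two cores is not broken down here. In this assay compound 2 gives 54.6%. Compound 4 `Cc1cccc(/C(N)=N/NC(=S)N2CCOCC2)n1` is compound 2 with the same change, (morpholin-4-yl in place of thiomorpholin-4-yl on a thiocarbonyl carbon). The earlier step of a number 4.3 percentage points higher from compound 3 to compound 1 (within the scatter) stayed within the scatter. On that basis the step expected here is a number 2.4 percentage points higher from compound 2 to compound 4 (within the scatter). Compound 4 is therefore estimated at 57%, between 46% and 68%.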

Compound 4, percent growth inhibition at one concentration: 65.7%
For compound 4 the middle estimate is 8.7 percentage points below the measured one; the range from low to high includes it.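

In this assay, morpholin-4-yl in place of thiomorpholin-4-yl on a thiocarbonyl carbon gives a number 11.1 percentage points higher from compound 2 to compound 4 (beyond the scatter). Set beside the earlier step on the other core, the change carries over without a gap larger than repeated measurements would produce: the same change on two cores in this assay, a number 4.3 percentage points higher (within the scatter) from compound 3 to compound 1 and a number 11.1 percentage points higher (beyond the scatter) from compound 2 to compound 4, 6.8 percentage points apart, within the scatter of two such steps. This does not show that the change works more strongly on one core than on the other, and two pairs cannot say why it acts or whether it would hold on further cores.

The compounds shown leave open how a piperazine ring or a simple dimethylamino group on the thiocarbonyl carbon would compare with these two rings. They also leave open whether the step survives on a core carrying an ethyl group in place of the methyl.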